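This account rests on a few compounds, and the source may have more. Where it says the series, first, only, none or still open, it means among the compounds named here.

Compound 3 `Cn1nc2c(=O)n(CC3(O)CCN(Cc4ccc(-c5ccoc5)cc4Cl)CC3)cnc2c1-c1ccc(CN)cc1` gives 177 nM in an assay on isolated protein for inhibition of ubiquitin carboxyl-terminal hydrolase 7 (Homo sapiens), with stated times of 30 min and 2 h (a higher number here means a weaker inhibitor, a lower number a stronger inhibitor), the second highest of the three numbers at hand. Going by the values given here, compound 2 `Cn1nc2c(=O)n(CC3(O)CCN(Cc4ccc(-c5ccco5)cc4Cl)CC3)cnc2c1-c1ccc(CNS(C)(=O)=O)cc1` gives 65.3 nM in this assay, and compound 1 `Cn1nc2c(=O)n(CC3(O)CCN(Cc4ccc(-c5ccco5)cc4Cl)CC3)cnc2c1-c1ccc(C(F)(F)F)cc1` gives 530 nM; the single step measured in one place is an 8.1-fold lower number from compound 1 to compound 2 (0.91 log units; beyond the scatter), a modest one. Compound 4 `Cc1ccc(-c2ccc(CN3CCC(O)(Cn4cnc5c(-c6ccc(CN)cc6)n(C)nc5c4=O)CC3)c(Cl)c2)s1` has not yet been measured; it differs from compound 3 in one place: 5-methylthiophen-2-yl in place of furan-3-yl on an aromatic carbon. Among the compounds with values here, no measured step bears on this change. Within the data shown here, the step from compound 1 to compound 2 concerns the other aromatic substituent, and compounds 2 and 3 differ in two places at once, so their values show only that both lie beneath compound 1 without separating the two changes. With nothing to guide the direction, the step from compound 3 to compound 4 is expected to be a 1.2-fold lower number from compound 3 to compound 4 (0.07 log units; within the scatter), none beyond the scatter. Compound 4 is therefore estimated at 150 nM, with a range from 50 nM to 450 nM.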

Compound 4, half-maximal inhibitory concentration: 101 nM
For compound 4 the middle estimate is 1.5-fold (0.17 log units) above the measured one; the range from low to high includes it.
By their numbers in this assay, from the lowest: compounds 2, 4 and 3 (each within the scatter of the next, the first and the last beyond it); then compound 1.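

In this assay, 5-methylthiophen-2-yl in place of furan-3-yl gives a 1.8-fold lower number from compound 3 to compound 4 (0.24 log units; within the scatter). Going by these compounds alone, this is the first step read at this position, on the six-membered aromatic ring of carbon only and para to a large group, and it shows that a group of 6 heavy atoms with sulfur can replace one of 5 heavy atoms with oxygen without a shift beyond the scatter. Nothing measured on these compounds explains the result.

From the compounds shown here alone, the methyl group, the sulfur and the point of attachment all change together in this one step, and which of them, if any, matters remains open. Also open, going by these compounds, is how this position would respond to a more different group, such as a carboxylic acid or a morpholine.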